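The compounds below may be only part of what the source reports. "The series", "measured", "known", "first", "only" and "open" are said of these compounds alone.

Three ureas built on a shared core have been examined in a functional assay on RPMI-8226 cells (Homo sapiens) for inhibition; a lower number here means a stronger inhibitor, a higher number a weaker inhibitor. Compound 1 `N#CC1CN1C(=O)NCc1ccccc1` gives 11000 nM. Compound 3 `CCCCNC(=O)N1CC1C#N` gives 17000 nM in this assay, the higher of the two numbers obtained, though compound 1 lies close to it, within the usual scatter. For compound 2 `N#CC1CN1C(=O)Nc1ccc(S(N)(=O)=O)cc1` only a limit has been reported in this assay, namely > 38000 nM.

Compound 4 `CC(C)(C)NC(=O)N1CC1C#N` has not yet been measured. It differs from compound 3 by tert-butyl in place of butyl on an amide-type nitrogen. For the measured compounds named here, no measured pair shows this kind of change, so the expectation rests on compound 3 alone, with its value of 17000 nM. The estimated step is a 1.2-fold higher number from compound 3 to compound 4 (0.07 log units; within the scatter), which is not expected to exceed the scatter. Compound 4 is therefore estimated at 20000 nM, with a range from 8000 nM to 50000 nM.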

Compound 4, half-maximal inhibitory concentration: 216000 nM
Compound 4: the middle estimate sits 11-fold (1.03 log units) below what was measured; the whole stated range lies below it.
By their numbers in this assay, from the lowest: compounds 1 and 3 (each within the scatter of the next); then compound 4.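

In this assay, tert-butyl in place of butyl on an amide-type nitrogen gives a 13-fold higher number from compound 3 to compound 4 (1.10 log units; beyond the scatter), although the two groups hold the same atoms, joined differently. For the compounds shown here, the earlier compounds offered no step at this position, so this is the first sign that the arrangement of the chain matters here, and not only the atoms it contains.

Whether branching alone accounts for this stays open, with neither isopropyl nor sec-butyl on this nitrogen among the compounds shown. Compound 2 has only a limit, which offers no number for comparison: the limit of > 38000 nM in this assay, at which 1 of the 4 values shown sits.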